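Methoxymethyl in Place of Hydrogen on an Aromatic Carbon

The source may report more compounds than this note shows. Statements on the series, on what has been measured and on what is new or still open speak of the compounds shown alone.

Compound 1, `C=CCn1ncc2cncn2c1=O`, in a functional assay for inhibition, with Homo sapiens as the target (a higher number here means a weaker inhibitor, a lower number a stronger inhibitor), gives > 48000 nM, which is a limit of the assay and not a number.
Compound 2, `C=CCn1ncc2c(C)ncn2c1=O`, in this assay gives > 48000 nM, again a limit of the assay.
Compound 3, `C=CCn1ncc2c(CC)ncn2c1=O`, in this assay gives > 48000 nM, also a limit of the assay.

Compound 1 thus stands only at a limit in this assay; no number for it is known, and the same holds for the two other measured compounds. Compound 4, `C=CCn1ncc2cnc(COC)n2c1=O`, differs from compound 1 in one place: methoxymethyl in place of hydrogen on an aromatic carbon. The measured steps that bear on this change are those in which methyl or ethyl enters at the same aromatic carbon of the core of compound 1: a step that the two limits leave unreadable from compound 1 to compound 2 and a step that the two limits leave unreadable from compound 1 to compound 3. Neither can be read, because of the limit of > 48000 nM in this assay, at which 3 of the 3 values shown sit. The step that the two limits leave unreadable from compound 2 to compound 3 is equally unreadable. No size or direction of a step can therefore be derived from the data; all that is seen is that hydrogen, methyl and ethyl at this carbon each leave the compound at the limit. Compound 4 is accordingly expected to remain at or near that limit, and the step that the limit leaves unreadable from compound 1 to compound 4 is expected to be small. Compound 4 is estimated at 60000 nM, with a range from 20000 nM to 200000 nM, and most probably it will again be reported only as a limit.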

Compound 4, half-maximal inhibitory concentration: > 48000 nM
Compound 4 ended at the assay's limit; the forecaster's own chance of this, stated with the estimate: 85%; the middle value does not contradict the limit.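

No new step can be read between compound 1 and compound 4 in this assay, because both compounds stand only at a limit, as do the others shown: the limit of > 48000 nM in this assay, at which 4 of the 4 values shown sit. The compounds shown leave open whether any group on the core of compound 1 can bring a compound to a readable value.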